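The compounds below may be only part of what the source reports. "The series", "measured", "known", "first", "only" and "open" are said of these compounds alone.

Working notes on the series. In a functional assay on SK-OV-3 cells (Homo sapiens) for cytotoxicity, read by sulforhodamine B assay, with a stated time of 2 days, tested at 100 uM (on this read-out lower numbers stand for less inhibition and higher numbers for more inhibition at the one concentration tested (going by the name of the read-out)), compound 1 `O=C(Nn1c(-c2cccc([N+](=O)[O-])c2)nc2c(-c3ccc(Cl)cc3)n[nH]c2c1=O)c1cccnc1` gives 30.2%. Compound 2 `O=C(Nn1c(-c2cccc([N+](=O)[O-])c2)nc2c(-c3ccc(F)cc3)n[nH]c2c1=O)c1cccnc1` differs from it by fluoro in place of chloro on an aromatic carbon, and the step of a number 10.9 percentage points lower from compound 1 to compound 2 (beyond the scatter). Compound 3 `COc1cccc(-c2nc3c(-c4ccc(C5CCNCC5)cc4)n[nH]c3c(=O)n2NC(=O)c2ccncc2)c1`, built on a different substituent pattern around the shared core, gives 18.2% in this assay. Among these three numbers compound 2, at 19.3%, stands second highest; compound 3 lies within the scatter of it, and compound 1 is the only one separated from it beyond the scatter.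

Compound 4 `O=C(Nn1c(-c2cccc([N+](=O)[O-])c2)nc2c(-c3ccco3)n[nH]c2c1=O)c1cccnc1` is the next member to be measured. Its change from compound 2 is furan-2-yl in place of 4-fluorophenyl on an aromatic carbon. Among the compounds with values here, the only measured step at this aromatic carbon is the halogen exchange from compound 1 to compound 2, a modest shift beyond the scatter. Within the data shown here, no measured pair carries furan-2-yl or exchanges a six-membered ring for a five-membered one at this place, so there is no direct precedent. The halogen step shows the position is not inert but gives no direction for a ring exchange. For compound 4 the expected step is a number 0.7 percentage points higher from compound 2 to compound 4 (within the scatter), which may fall either way and is as likely as not to stay within the scatter. The estimate for compound 4 in this assay is 20%, with a range from 8% to 34%.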

Compound 4, a percentage reported as inhibition, at one concentration (the size of the read-out at that concentration, not a potency): -0.61%
The estimate for compound 4 lay 20.6 percentage points above the measured number; measured number below the stated range.
By their numbers in this assay, from the lowest: compound 4; then compounds 3 and 2 (each within the scatter of the next); then compound 1.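

In this assay, the exchange of the aromatic ring at this carbon has a clearer effect than the halogen exchange alone could show: furan-2-yl in place of 4-fluorophenyl gives a number 19.9 percentage points lower from compound 2 to compound 4 (beyond the scatter), and furan-2-yl in place of 4-chlorophenyl gives a number 30.8 percentage points lower from compound 1 to compound 4 (beyond the scatter). Both halogen-bearing phenyl compounds retain a measurable inhibition at the one concentration tested, whereas compound 4 gives -0.61%, so the read-out at this position depends on the ring itself and not only on its halogen. Nothing available bears on why the furan-2-yl compound behaves in this way.

The compounds shown change the ring size, the ring hetero atom and the presence of a halogen together, so they leave open which of these differences accounts for the drop. Unsubstituted phenyl would separate the loss of the halogen from the ring exchange, thiophen-2-yl would test another five-membered aromatic ring with a sulfur atom in place of oxygen, and a 4-aminophenyl group would show how an amine compares with the halogens on the same six-membered ring.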